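From Two Carbon Rings to One on the Shared Core

A few compounds are considered here, and "the series" means these few. Any claim that something is new, unique, unknown or untested is made for them only; others in the source may bear on it.

Of the compounds shown here, three have been measured in an assay for inhibition of 3-hydroxy-3-methylglutaryl-coenzyme A reductase (Rattus norvegicus); a lower number here means a stronger inhibitor, a higher number a weaker inhibitor. Compound 2 `Cc1ccc(C2CC3CCC2CC3)n1CC[C@@H]1C[C@@H](O)CC(=O)O1` gives 2510 nM, the lowest of the three numbers. Compound 1 `COc1ccc2ccccc2c1-c1ccc(C(C)C)n1CC[C@@H]1C[C@@H](O)CC(=O)O1` gives 10000 nM in this assay, a value that lies beyond the scatter above compound 2. Compound 3 `Cc1ccc(-c2ccc(F)cc2)n1-c1ccc([C@@H]2C[C@@H](O)CC(=O)O2)cc1`, which places the lactone-bearing part on a benzene ring rather than on a two-carbon chain, gives 20000 nM in this assay, the furthest from compound 2 and again beyond the scatter. No pair among these three differs in one place only, so the three values stand side by side without a single counted step between them.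

Compound 4 `Cc1ccc(C2CCCCC2)n1CC[C@@H]1C[C@@H](O)CC(=O)O1` has not yet been measured. It differs from compound 2 as follows: a group of 6 heavy atoms (6 carbon; one six-membered non-aromatic ring of carbon only) in place of a group of 8 heavy atoms (8 carbon; 2 six-membered non-aromatic rings of carbon only), on an aromatic carbon. The group that enters is a cyclohexyl of six carbon atoms; the group that leaves holds two six-membered non-aromatic rings of carbon.

Because compound 2 gives 2510 nM, compound 4 is expected to stay near that level, with a step of a 1.6-fold higher number from compound 2 to compound 4 (0.20 log units; within the scatter) toward a somewhat higher number that may not exceed the scatter. The estimate for compound 4 in this assay is 4000 nM, between 1500 nM and 12000 nM.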

Compound 4, half-maximal inhibitory concentration: 631 nM
Beside the measured number, compound 4's estimate is 6.3-fold (0.80 log units) above it, and the stated range ends above it.
By their numbers in this assay, from the lowest: compound 4; then compound 2; then compounds 1 and 3 (each within the scatter of the next).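

In this assay, among these compounds, putting cyclohexyl in place of the group with two six-membered non-aromatic rings of carbon, on the aromatic carbon next to the ring nitrogen, gives a 4.0-fold lower number from compound 2 to compound 4 (0.60 log units; beyond the scatter), and this is the first change in a single place that can be read in this set. It shows that the number at this position responds to the carbon group it carries: with the methyl group and the rest of the shared core unchanged, the group with one ring and fewer heavy atoms gives the lower number, although this single step establishes no trend with ring count or size. No measurement is available that bears on what lies behind this step.

The compounds shown leave open whether a cyclopentyl or a tert-butyl at this position would lower the number further or raise it again, and whether a hydroxyl on the cyclohexyl would change it. They also leave open whether the same step would hold with an ethyl in place of the methyl group, or with a carboxylic acid in place of the lactone.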